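A few compounds are considered here, and "the series" means these few. Any claim that something is new, unique, unknown or untested is made for them only; others in the source may bear on it.

Working notes on the series. In an ADME assay on HEK293 cells (Homo sapiens) for cytotoxicity, read by MTT assay, with a stated time of 72 h (on this read-out lower numbers stand for stronger inhibition and higher numbers for weaker inhibition), compound 1 (`O=C(CN1CCN(C(=O)c2cccc(Cl)c2)CC1)N1CCN(CCCc2c[nH]c3ccccc23)CC1`) gives 99100 nM and compound 2 (`COc1ccc(C(=O)N2CCN(CC(=O)N3CCN(CCCc4c[nH]c5ccc(F)cc45)CC3)CC2)cc1`) gives 141000 nM. Within the data shown here, these two values lie within the scatter of each other, so compound 2 cannot be ranked against compound 1 on the numbers so far.

The next entry is compound 3 (`O=C(CN1CCN(C(=O)c2cccc(Cl)c2)CC1)N1CCN(CCCc2c[nH]c3ccc(F)cc23)CC1`), not yet measured in this assay. Its change from compound 2 is 3-chlorophenyl in place of 4-methoxyphenyl on a carbonyl carbon. Among the measured compounds shown here, the data hold no step between measured compounds that differ in one place, so this change has no direct precedent. For the measured compounds named here, the only guide is the narrow spread so far, with compound 2 at 141000 nM and compound 1, which also carries 3-chlorophenyl on a carbonyl carbon, at 99100 nM.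

The expected size is a 1.2-fold lower number from compound 2 to compound 3 (0.09 log units; within the scatter), which would be no shift beyond the scatter in either direction. For compound 3 the estimated value in this assay is 115000 nM, with an expected range of 55000 nM to 240000 nM.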

Compound 3, half-maximal inhibitory concentration: 66200 nM
The estimate for compound 3 lay 1.7-fold (0.24 log units) above the measured number; the measured number falls inside the stated range.
By their numbers in this assay, from the lowest: compounds 3, 1 and 2 (each within the scatter of the next, the first and the last beyond it).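

In this assay, among these compounds, this is the first reading of a single change at this position, on a carbonyl carbon whose other neighbour is an amide-type nitrogen in a ring: 3-chlorophenyl in place of 4-methoxyphenyl gives a 2.1-fold lower number from compound 2 to compound 3 (0.33 log units; beyond the scatter), so the group at this position can move the number beyond the scatter, though only modestly. Fluoro in place of hydrogen on an aromatic carbon gives a 1.5-fold lower number from compound 1 to compound 3 (0.18 log units; within the scatter), so this second change shows no separable shift in this pair. No measurement shown here accounts for either step.

The compounds shown leave open whether the step at the carbonyl carbon follows from the chlorine, from the loss of the methoxy group or from the place of the group on the phenyl ring, a question that 4-chlorophenyl and 3-methoxyphenyl would separate. They also leave open how an aminophenyl or a carboxyphenyl group at this position would read, and whether the step from 4-methoxyphenyl to 3-chlorophenyl holds with hydrogen in place of the fluoro.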